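Removing methoxymethyl from compound 2

The source may report more compounds than this note shows. Statements on the series, on what has been measured and on what is new or still open speak of the compounds shown alone.

In an ADME assay on KB cells (Homo sapiens) for cytotoxicity, read by MTT assay, with a stated time of 72 h (on this read-out lower numbers stand for stronger inhibition and higher numbers for weaker inhibition), compound 1 `COc1ccc(C2=C(c3cc(OC)c(OC)c(OC)c3)C(=O)CC2O[SiH2]C(C)(C)C)cc1OC` gives only a limit, > 100 ug/mL. For the measured compounds named here, compound 2 `COCOc1cc(C2=C(c3cc(OC)c(OC)c(OC)c3)C(=O)CC2O[SiH2]C(C)(C)C)ccc1OC` gives 33 ug/mL, the only actual number so far. Compound 3 `COc1ccc(C2=C(c3cc(OC)c(OC)c(OC)c3)C(=O)CC2O[SiH2]C(C)(C)C)cc1O` carries hydrogen in place of methoxymethyl on an oxygen on an aromatic ring. Going by the values given here, the one measured step at this oxygen is an at least 3.0-fold lower number from compound 1 to compound 2 (0.48 log units; beyond the scatter), which lies beyond the scatter in this assay. That step involves no free hydroxy, so it sets no direction, and no step beyond the scatter is expected. The expected step is a 1.1-fold lower number from compound 2 to compound 3 (0.04 log units; within the scatter). Compound 3 is estimated at 30 ug/mL, with an expected range of 6 ug/mL to 100 ug/mL.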

Compound 3, half-maximal inhibitory concentration: 6.5 ug/mL
Estimate against measurement, compound 3: 4.6-fold (0.66 log units) above; measured number inside the range.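

In this assay, hydrogen on this oxygen on an aromatic ring gives the lowest number of the three compounds: a 5.1-fold lower number from compound 2 to compound 3 (0.71 log units; beyond the scatter), and an at least 15-fold lower number from compound 1 to compound 3 (1.18 log units; beyond the scatter). Both methoxymethyl and methyl at this oxygen therefore go with higher numbers than the free hydroxy, a contrast that the earlier pair, with both oxygens capped, could not show. The value of compound 1 is a limit of the assay, and the size of the second step rests on it: the limit of > 100 ug/mL in this assay, at which 1 of the 3 values shown sits.

The compounds shown leave open whether the gain is specific to the hydroxy. An amine at this ring position, or a longer chain such as ethyl on this oxygen, would bear on that question.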